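A few compounds are considered here, and "the series" means these few. Any claim that something is new, unique, unknown or untested is made for them only; others in the source may bear on it.

Measured in a functional assay on HEK293 cells for antagonist activity at metabotropic glutamate receptor 5 (Rattus norvegicus), read by calcium flux; a higher number here means a weaker inhibitor, a lower number a stronger inhibitor:
compound 1 `Fc1cccc(Nc2ncnc3ccc(Br)cc23)c1`: 1970 nM
compound 2 `COc1cccc(Nc2ncnc3ccc(Br)cc23)c1`: a limit of the assay, > 10000 nM
compound 3 `Fc1ccc2ncnc(Nc3cccc(Cl)c3)c2c1`: 311 nM

Compound 3 gives the lowest of the two numbers; how its core differs from that of compound 1 is not broken down here. Compound 1 to compound 2 is methoxy in place of fluoro on an aromatic carbon, and the step is an at least 5.0-fold higher number from compound 1 to compound 2 (0.70 log units; beyond the scatter), compound 2 sitting at the limit of > 10000 nM in this assay, at which 1 of the 3 values shown sits. Compound 4 `COc1ccc2ncnc(Nc3cccc(Cl)c3)c2c1`, not yet measured, differs from compound 3 by methoxy in place of fluoro on an aromatic carbon. This is the same kind of change as from compound 1 to compound 2, not the same: there the place is on a six-membered aromatic ring of carbon only, meta to a large group; here the ring is part of a fused or bridged system of two rings, meta to a fused ring and para to a fused ring. Going by the values given here, for compound 4 a step of comparable direction is expected, a 6.4-fold higher number from compound 3 to compound 4 (0.81 log units; beyond the scatter), because an at least 5.0-fold higher number from compound 1 to compound 2 (0.70 log units; beyond the scatter) is the only precedent. The estimate for compound 4 in this assay is 2000 nM, between 500 nM and 10000 nM, with a real chance of only a limit.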

Compound 4, half-maximal inhibitory concentration: 1510 nM
Compound 4: middle estimate off by 1.3-fold (0.12 log units), on the high side, within the range that was stated.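

In this assay, methoxy in place of fluoro on an aromatic carbon gives a 4.9-fold higher number from compound 3 to compound 4 (0.69 log units; beyond the scatter), the same direction as on the core of compound 1, although the place on the ring is not the same in the two pairs. The direction therefore holds on these two cores, but this shows neither that the two steps are equal in size nor that the change would behave alike on a third core: the same change on two cores in this assay, an at least 5.0-fold higher number (0.70 log units; beyond the scatter) from compound 1 to compound 2 and a 4.9-fold higher number (0.69 log units; beyond the scatter) from compound 3 to compound 4; the limit leaves it open whether they differ Compound 2 gives > 10000 nM, which is a limit of the assay.

Still open, as far as these compounds go, is how a hydroxyl, an amine or a longer chain such as ethoxy would compare with fluoro and methoxy at the place changed in compound 4. Also open, from the compounds shown here alone, is whether such a group would give a step in the same direction on the core of compound 1.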